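From an Amino Ring to a Bromine on the Shared Core

The source may report more compounds than this note shows. Statements on the series, on what has been measured and on what is new or still open speak of the compounds shown alone.

The compounds here share one core and differ only in what hangs from it. Compound 1 `N#Cc1cc(NCc2ccccc2[N+](=O)[O-])c2cn[nH]c2c1` carries a nitrile on the core and a nitro group on the other ring. In an assay for inhibition of Tryptophan 2,3-dioxygenase (Homo sapiens), with stated times of 10 min and 60 min (on this read-out lower numbers stand for stronger inhibition and higher numbers for weaker inhibition), compound 1 gives > 100000 nM, which is a limit of the assay rather than a number. Compound 2 `O=C(O)CNc1cccc(CNc2cc(C(F)(F)F)cc3[nH]ncc23)c1` bears a trifluoromethyl on the core and a carboxymethyl on a nitrogen of the other ring. In this assay compound 2 gives > 100000 nM, again a limit. Compound 3 `OC1CCCC(Nc2cccc(CNc3cc(C(F)(F)F)cc4[nH]ncc34)c2)C1` carries a 3-hydroxycyclohexyl where compound 2 carries the carboxymethyl. In this assay compound 3 gives > 100000 nM, also a limit. All three readings shown sit at the same place, (the limit of > 100000 nM in this assay, at which 3 of the 3 values shown sit), so compound 3 stands level with the others rather than above or below them. The step that the two limits leave unreadable from compound 2 to compound 3 therefore cannot be read. Compound 4 `FC(F)(F)c1cc(NCc2cccc(Br)c2)c2cn[nH]c2c1` differs from compound 3 by bromo in place of (3-hydroxycyclohexyl)amino on an aromatic carbon. No measured step covers this change, and none of the shown values is a number, so no direction can be drawn from them. Compound 4 is expected to give 100000 nM, between 20000 nM and 300000 nM. The expected step is a number no higher from compound 3 to compound 4 (the limit leaves the size open), and most likely this assay again reports only a limit.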

Compound 4, half-maximal inhibitory concentration: 19100 nM
Estimate against measurement, compound 4: 5.2-fold (0.72 log units) above, and the stated range ends above it.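

Bromo in place of (3-hydroxycyclohexyl)amino on an aromatic carbon gives an at least 5.2-fold lower number from compound 3 to compound 4 (0.71 log units; beyond the scatter) in this assay, so this position can respond to a change in a way that the earlier compounds could not show. Bromo in place of (carboxymethyl)amino on that same carbon gives an at least 5.2-fold lower number from compound 2 to compound 4 (0.71 log units; beyond the scatter), which means that a single bromine atom, with no ring and no hydrogen-bond donors, yields a real number where the two larger amino-bearing groups yield only a limit. Both steps start from a limit, so each sets only a smallest possible size, and compound 4 remains the one reading in this set that is a number:  the limit of > 100000 nM in this assay, at which 3 of the 4 values shown sit.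

Going by these compounds, whether the improvement belongs to the bromine itself or simply to the loss of the amino-bearing groups stays open, and a chlorine or a methyl on this carbon would help to separate the two. Also open, on these data alone, is whether a plain amine or a carboxylic acid set directly on this carbon would give a number or would stay at the limit.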